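The compounds below may be only part of what the source reports. "The series", "measured", "known", "first", "only" and "open" are said of these compounds alone.

Measured so far in a functional assay on UO-31 cells (Homo sapiens) for inhibition, read by sulforhodamine B assay, with a stated time of 48 h; a higher number here means a weaker inhibitor of growth, a lower number a stronger inhibitor of growth: compound 1 `COc1cc(-c2nn(-c3cccc(NC(=O)Nc4cc(C(F)(F)F)cc(C(F)(F)F)c4)c3)cc2-c2ccncc2)ccc1Cl`, 600 nM; compound 2 `COc1cc(-c2nn(-c3cccc(NC(=O)Nc4ccc(Cl)c(Cl)c4)c3)cc2-c2ccncc2)ccc1Cl`, 845 nM; compound 3 `O=C(Nc1cccc(-n2cc(-c3ccncc3)c(-c3ccc(Cl)c(O)c3)n2)c1)Nc1ccc(Cl)c(Cl)c1`, 1250 nM.

For the measured compounds named here, compound 2 stands between the other two on these numbers, and none of the three is separated from another beyond the usual scatter; the one single-point step, a 1.5-fold higher number from compound 2 to compound 3 (0.17 log units; within the scatter), concerns the oxygen substituent and is itself within the scatter. Compound 4 `COc1cc(-c2nn(-c3cccc(NC(=O)c4ccc(Cl)c(C(F)(F)F)c4)c3)cc2-c2ccncc2)ccc1Cl` carries a different change: 4-chloro-3-(trifluoromethyl)phenyl in place of (3,4-dichlorophenyl)amino on a carbonyl carbon. Going by the values given here, no measured step touches this carbonyl neighbour, so the step from compound 2 to compound 4 is estimated from the narrow spread of all three measured values alone, and no movement beyond the scatter is expected: a 1.1-fold lower number from compound 2 to compound 4 (0.05 log units; within the scatter). Compound 4 is therefore expected to give about 750 nM, with a plausible range of 250 nM to 2200 nM.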

Compound 4, concentration for 50% growth inhibition: 267 nM
Estimate against measurement, compound 4: 2.8-fold (0.45 log units) above, within the range that was stated.
By their numbers in this assay, from the lowest: compound 4; then compounds 1, 2 and 3 (each within the scatter of the next, the first and the last beyond it).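

In this assay, for the compounds shown here, the exchange of (3,4-dichlorophenyl)amino for 4-chloro-3-(trifluoromethyl)phenyl on a carbonyl carbon gives a 3.2-fold lower number from compound 2 to compound 4 (0.50 log units; beyond the scatter) and is the first step here to lie beyond the scatter, so this position responds where the step at the oxygen substituent did not. The exchange removes a hydrogen-bond donor and the amino link while also altering the ring substituents, and this single step cannot separate those changes. Nothing available explains the shift.

Left open is what (4-chloro-3-(trifluoromethyl)phenyl)amino on the same carbonyl carbon would give, which would separate the amino link from the ring substituents. A plain phenyl there would show whether the halogens and trifluoromethyl matter at all.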